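Swapping the aryl group on a dihydropyridine calcium channel blocker

This account rests on a few compounds, and the source may have more. Where it says the series, first, only, none or still open, it means among the compounds named here.

Measured compounds:
- Compound 1 `COC(=O)c1cccc(C2C(C(=O)O)=C(C)N=C(C)/C2=C(/O)OC/C=C/c2ccccc2)c1`: 4600 nM
- Compound 2 `CC1=NC(C)=C(C(=O)O)C(c2cccc(Br)c2)/C1=C(\O)OC/C=C/c1ccccc1`: 790 nM

Of the compounds shown here, two sharing one core have been tested in a functional assay on IMR-32 cells for inhibition of Voltage-dependent N-type calcium channel subunit alpha-1B (Homo sapiens), read by calcium flux; on this read-out lower numbers stand for stronger inhibition and higher numbers for weaker inhibition. Compound 1 gives the highest of the two numbers, 4600 nM, so it is the weaker inhibitor here. Within the data shown here, compound 2 reaches 790 nM, and the single measured step is a 5.8-fold lower number from compound 1 to compound 2 (0.77 log units; beyond the scatter).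

The unmeasured compound 3 `CC1=NC(C)=C(C(=O)O)C(c2cccnc2)/C1=C(\O)OC/C=C/c1ccccc1` differs from compound 1 at the same saturated ring carbon: pyridin-3-yl in place of 3-(methoxycarbonyl)phenyl on a saturated ring carbon.

Among the measured compounds shown here, only the step from compound 1 to compound 2 bears on this change. It shows that removing the methoxycarbonyl from the aromatic ring at this position is tolerated and lowers the number by a modest amount. For the measured compounds named here, compound 3 also loses the methoxycarbonyl, but the ring itself changes from a carbon-only aromatic ring to one with a nitrogen, for which no measured step exists. The expectation is therefore a downward step for compound 3 of roughly the same size, with wide uncertainty: a 2.3-fold lower number from compound 1 to compound 3 (0.36 log units; beyond the scatter).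

The estimate for compound 3 in this assay is 2000 nM, within 600 nM to 7000 nM.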

Compound 3, half-maximal inhibitory concentration: 24000 nM
Estimate against measurement, compound 3: 12-fold (1.08 log units) below; measured number above the stated range.
By their numbers in this assay, from the lowest: compound 2; then compound 1; then compound 3.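

At this saturated ring carbon in this assay, the aromatic group strongly sets the read-out, and pyridin-3-yl is the least favourable of the three groups tested: there is a 5.2-fold higher number from compound 1 to compound 3 (0.72 log units; beyond the scatter), and a larger 30-fold higher number from compound 2 to compound 3 (1.48 log units; beyond the scatter). Losing the methoxycarbonyl therefore does not by itself bring a lower number, since compound 2 and compound 3 both lack that group yet lie far apart, with compound 3 on the weaker side of both neighbours. Nothing measured here accounts for this rise in the number.

Compound 3 differs from compound 2 in two features at once, a ring nitrogen in place of a ring carbon and no bromo substituent, so these compounds cannot show how much of the step belongs to each. A plain phenyl group would help separate the two features, while a 3-chlorophenyl or a 3-aminophenyl group at the same carbon would show whether the low number of compound 2 is specific to bromo.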